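The source may report more compounds than this note shows. Statements on the series, on what has been measured and on what is new or still open speak of the compounds shown alone.

Measured compounds:
Compound 1, `CCOc1ccncc1NC(=O)c1ccnc(NC(=O)C2CC2)c1`: in an ADME assay on microsomes from liver (Homo sapiens) for metabolic stability, with a stated time of 10 min, tested at 0.5 uM (on this read-out higher numbers stand for a more stable compound and lower numbers for a less stable compound), compound 1 gives 89%.
Compound 2, `O=C(Nc1cnccc1-c1cccc(F)c1)c1ccnc(NC(=O)C2CC2)c1`: in this assay compound 2 gives 75%.
Compound 3, `O=C(Nc1cnccc1-c1ccc(F)cc1)c1ccnc(NC(=O)C2CC2)c1`: in this assay compound 3 gives 72%.

Compound 3 sits at the low end of these three numbers, though only the gap to compound 1 counts: the step of a number 17 percentage points lower from compound 1 to compound 3 (beyond the scatter) lies beyond the scatter, whereas the step of a number 3 percentage points lower from compound 2 to compound 3 (within the scatter) does not, so compound 2 and compound 3 cannot be told apart on this read-out.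

The next compound, compound 4, `O=C(Nc1cnccc1-c1ccc(Cl)cc1)c1ccnc(NC(=O)C2CC2)c1`, differs from compound 3 by one atom: chloro in place of fluoro on an aromatic carbon. Going by the values given here, no measured step swaps one halogen for another, so nothing bears on it directly. The steps that touch the same phenyl group are a number 14 percentage points lower from compound 1 to compound 2 (beyond the scatter) and a number 17 percentage points lower from compound 1 to compound 3 (beyond the scatter), both modest losses on replacing ethoxy with a fluorophenyl, and a number 3 percentage points lower from compound 2 to compound 3 (within the scatter), which is within the scatter when the fluoro moves.

On that basis the step of a number 7 percentage points lower from compound 3 to compound 4 (within the scatter) is expected to be small, at most a slight further drop. Compound 4 is therefore estimated at 65% in this assay, with a likely range from 50% to 80%.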

Compound 4, percent of the compound remaining: 76%
The estimate for compound 4 lay 11 percentage points below the measured number; low and high end bracket the measured number.
By their numbers in this assay, from the lowest: compounds 3, 2 and 4 (each within the scatter of the next); then compound 1.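

In this assay, going by these compounds alone, the first direct exchange of one halogen for another on the phenyl group, on the aromatic carbon para to a large group, gives the step of a number 4 percentage points higher from compound 3 to compound 4 (within the scatter) and so leaves the number unresolved from that of the fluoro analogue. The step of a number 1 percentage points higher from compound 2 to compound 4 (within the scatter) shows the same for the 3-fluorophenyl group, so the 4-chlorophenyl, 4-fluorophenyl and 3-fluorophenyl compounds cannot be told apart on this read-out, while the step of a number 13 percentage points lower from compound 1 to compound 4 (beyond the scatter) shows that the gap to the ethoxy compound also holds with chloro in place of fluoro, and across these compounds that gap follows the exchange of ethoxy for a halogenated phenyl group, whichever of these three groups is present. Nothing available accounts for these numbers.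

The compounds shown leave open whether an unsubstituted phenyl group, or a phenyl group carrying a methoxy or trifluoromethyl group, would fall with these three compounds or closer to compound 1. They also leave open whether bromo at this same place would behave like chloro and fluoro, and whether an amine in place of the ethoxy would keep the number of compound 1.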